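Solubility in a Thiazolidinone Series: From Cyclopropyl to a Lactam

The source may report more compounds than this note shows. Statements on the series, on what has been measured and on what is new or still open speak of the compounds shown alone.

The measured compounds are:

compound 1, `Cc1ccccc1N1C(=O)/C(=C/c2ccc(O)c(Cl)c2)S/C1=N\CCCF`, 20000 nM
compound 2, `CCC/N=C1\S/C(=C\c2ccc(O)c(Cl)c2)C(=O)N1C1CC1`, 79000 nM
compound 3, `CCC/N=C1\S/C(=C\c2ccc(O)c(C)c2)C(=O)N1c1ccccc1C`, 78000 nM

In a physicochemical assay for solubility, measured as kinetic solubility (on this read-out lower numbers stand for lower solubility and higher numbers for higher solubility), compound 2 gives 79000 nM. Among the three numbers it is at the top, but compound 3 gives 78000 nM, which lies within the usual scatter of compound 2, so the two cannot be told apart. Compound 1 gives 20000 nM, a gap to compound 2 that is beyond the scatter.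

Compound 4, `CCC/N=C1\S/C(=C\c2ccc(O)c(Cl)c2)C(=O)N1C1CCN(C)C(=O)C1`, has not yet been measured in this assay. It differs from compound 2 in one place: 1-methyl-2-oxopiperidin-4-yl in place of cyclopropyl on an amide-type nitrogen in a ring. Among the compounds with values here, no pair of measured compounds differing in one place is available, so there is no comparable step to lean on. The expected change in this assay from compound 2 to compound 4 is estimated as a 2.0-fold higher number from compound 2 to compound 4 (0.31 log units; beyond the scatter), a rise beyond the scatter, though with wide uncertainty. Compound 4 is accordingly expected to give about 160000 nM, within a range from 60000 nM to 400000 nM.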

Compound 4, solubility: > 250000 nM
Compound 4 ended at the assay's limit; the forecaster's own chance of this, stated with the estimate: 10%; middle value at least 1.5-fold (0.19 log units) away from the limit.
By their numbers in this assay, from the lowest: compound 1; then compounds 3 and 2 (each within the scatter of the next). At a limit, above all of these: compound 4.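

In this assay compound 4 gives > 250000 nM, which is a limit of the assay and not a number. Placing 1-methyl-2-oxopiperidin-4-yl in place of cyclopropyl on the amide-type nitrogen in the ring gives an at least 3.1-fold higher number from compound 2 to compound 4 (0.50 log units; beyond the scatter), so this position, two ring bonds from the ring sulfur, can carry a group of 8 heavy atoms rather than 3 with no loss on this read-out. The step is known from one side only, and its full size stays unread: the limit of > 250000 nM in this assay, at which 1 of the 4 values shown sits.

This single step cannot separate the parts played by the six-membered ring, its carbonyl and its methyl, nor show whether the change would carry over to compound 1 or compound 3. From the compounds shown here alone, how a plain piperidin-4-yl amine or a morpholine ring would read at this place remains open.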